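The source may report more compounds than this note shows. Statements on the series, on what has been measured and on what is new or still open speak of the compounds shown alone.

Measured so far in a physicochemical assay for solubility; a higher number here means a more soluble compound, a lower number a less soluble compound:
- compound 1 `Nc1cccc2c(=O)[nH]c(-c3ccc(C(F)(F)F)cc3)cc12`: > 30000000 nM (a limit)
- compound 2 `Nc1cccc2c(=O)[nH]c(-c3cccs3)cc12`: > 30000000 nM (a limit)

Compound 2 gives > 30000000 nM, which is a limit of the assay and not a number. Going by the values given here, the same holds for compound 1, so the two cannot be ranked, and no step between measured compounds is available. Among the compounds with values here, the only evidence is the limit of > 30000000 nM in this assay, at which 2 of the 2 values shown sit.

Compound 3 `Cc1cc2c(N)cccc2c(=O)[nH]1` is the next to be measured in this assay. It has methyl in place of thiophen-2-yl on an aromatic carbon, next to the ring nitrogen: methyl in place of thiophen-2-yl on an aromatic carbon.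

Within the data shown here, with the limit of > 30000000 nM in this assay, at which 2 of the 2 values shown sit, as the sole guide, the data give no measured size for this change. The working expectation is therefore no step beyond the scatter, with no direction assigned. The estimated step is a step that the limit leaves unreadable from compound 2 to compound 3. Another report as a limit is the expected outcome for compound 3, rather than a number.

The estimate for compound 3 is 35000000 nM, with an expected range of 15000000 nM to 70000000 nM.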

Compound 3, solubility: > 30000000 nM
Compound 3: a limit, no number; the forecaster's own chance of this, stated with the estimate: 80%; the middle value is on the limit's open side.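

In this assay compound 3 gives > 30000000 nM, which is a limit and not a number. Compound 2 is also reported only as a limit, so no step can be read between compound 2 and compound 3 for methyl in place of thiophen-2-yl. The compounds shown leave open how any of them rank, and the only guide remains: the limit of > 30000000 nM in this assay, at which 3 of the 3 values shown sit.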